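Compound 3: a fluorinated benzyl on a series at its limit

The source may report more compounds than this note shows. Statements on the series, on what has been measured and on what is new or still open speak of the compounds shown alone.

- compound 1 `Nc1ncnc2c1nc(NCc1ccc(Cl)c(Cl)c1)n2[C@@H]1O[C@H](COCc2ccccc2)[C@@H](O)[C@H]1O`: > 80000 nM
- compound 2 `N#Cc1ccc(COC[C@H]2O[C@@H](n3c(NCc4ccccc4)nc4c(N)ncnc43)[C@H](O)[C@@H]2O)cc1`: > 80000 nM

Compound 1 gives > 80000 nM in a functional assay on HCT-116 cells (Homo sapiens) for cytotoxicity, read by sulforhodamine B assay (on this read-out higher numbers stand for weaker inhibition of growth and lower numbers for stronger inhibition of growth), and that value is a limit, not a number. Compound 2 gives > 80000 nM and that value is also a limit. For the measured compounds named here, compound 1 stands at the limit of > 80000 nM in this assay, at which 2 of the 2 values shown sit, and no measured step is available. Compound 3 `Nc1ncnc2c1nc(NCc1ccc(Cl)c(Cl)c1)n2[C@@H]1O[C@H](COCc2cc(F)c(F)c(F)c2)[C@@H](O)[C@H]1O` keeps the core of compound 1 with one change: 3,4,5-trifluorophenyl in place of phenyl on a saturated chain carbon bound to an oxygen on a saturated carbon or, cut one bond further out, benzyl to 3,4,5-trifluorobenzyl. In this assay the expected step of an at least 1.3-fold lower number from compound 1 to compound 3 (0.12 log units; that floor lies within the scatter) is small and toward stronger inhibition of growth, and it may stay within the scatter. In this assay the estimate for compound 3 is 60000 nM with an expected range from 20000 nM to 80000 nM as a working figure.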

Compound 3, concentration for 50% growth inhibition: 13000 nM
Compound 3: the middle estimate sits 4.6-fold (0.66 log units) above what was measured; measured number outside the range, below it.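

Replacing benzyl with 3,4,5-trifluorobenzyl, on a saturated chain carbon bound to an oxygen on a saturated carbon, gives the only value off the limit among the compounds shown in this assay: an at least 6.1-fold lower number from compound 1 to compound 3 (0.78 log units; beyond the scatter). This position therefore responds to substitution on the phenyl ring, which compound 1 and compound 2, both at the limit, could not show. The step has only a lower bound because compound 1 gives a limit, not a number: the limit of > 80000 nM in this assay, at which 2 of the 3 values shown sit.

As far as these compounds go, whether a single fluorine, a chlorine or a methoxy group on the same ring gives a similar step stays open. So does the effect of a longer chain between the ring and the oxygen.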